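A methyl on the saturated ring of compound 1

The source may hold more compounds than are shown below. What is called first, only, known or untested is meant among the compounds shown, and "the series" means these compounds.

Measured in an ADME assay on A549 cells (Homo sapiens) for inhibition, read by MTT assay, with a stated time of 72 h; on this read-out higher numbers stand for weaker inhibition and lower numbers for stronger inhibition:
Compound 1 `COc1cc2ncnc(Nc3ccc(F)c(Cl)c3)c2cc1NC(=O)[C@@H]1COC(=O)N1`: 14900 nM
Compound 2 `COc1cc2ncnc(Nc3cccc(Br)c3)c2cc1NC(=O)[C@@H]1COC(=O)N1`: > 50000 nM, a limit of the assay
Compound 3 `CCOc1cc2ncnc(Nc3ccc(OCC4CC4)c(Cl)c3)c2cc1NC(=O)[C@@H]1COC(=O)N1`: 28900 nM

For the measured compounds named here, compound 1 at 14900 nM and compound 3 at 28900 nM lie within the scatter of each other, and these are the only two actual numbers in the set. Compound 2 reports only a limit, > 50000 nM.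

Compound 4 `COc1cc2ncnc(Nc3ccc(F)c(Cl)c3)c2cc1NC(=O)[C@H]1NC(=O)O[C@@H]1C` keeps the core of compound 1 and carries methyl in place of hydrogen on a saturated ring carbon, next to the ring oxygen, turning 2-oxo-1,3-oxazolidin-4-yl into 5-methyl-2-oxo-1,3-oxazolidin-4-yl: methyl in place of hydrogen on a saturated ring carbon.

Going by the values given here, the one measured step, an at least 3.3-fold higher number from compound 1 to compound 2 (0.52 log units; beyond the scatter), is beyond the scatter, but it exchanges 3-chloro-4-fluorophenyl for 3-bromophenyl on a nitrogen on an aromatic ring and leaves the saturated ring untouched. Among the compounds with values here, its size is therefore no direct guide here, and no measured step covers this ring. The expectation rests on compound 1 at 14900 nM, with no shift beyond the scatter foreseen in this assay. The expected change is a 1.2-fold higher number from compound 1 to compound 4 (0.08 log units; within the scatter). For compound 4 the estimate is 18000 nM, with an expected range of 7000 nM to 45000 nM.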

Compound 4, half-maximal inhibitory concentration: > 50000 nM
Compound 4 ended at the assay's limit (the forecaster's own chance of this, stated with the estimate: 15%); at least 2.7-fold (0.44 log units) between middle value and limit.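

In this assay, the saturated ring had stayed the same in compounds 1 to 3, so this methyl is the first change shown on that ring, and it gives an at least 3.3-fold higher number from compound 1 to compound 4 (0.52 log units; beyond the scatter). The step shows that this saturated ring carbon, next to the ring oxygen, is not indifferent to substitution: turning 2-oxo-1,3-oxazolidin-4-yl into 5-methyl-2-oxo-1,3-oxazolidin-4-yl, which adds a single carbon, weakens inhibition beyond the scatter, just as the exchange on the aromatic amine nitrogen had done in the earlier step. Compound 4 reports only a limit, > 50000 nM, so the step gives a lower bound and the full size of the loss remains unknown: the limit of > 50000 nM in this assay, at which 2 of the 4 values shown sit.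

The compounds shown leave open whether fluorine, hydroxymethyl or a longer chain such as ethyl on this ring carbon would behave as methyl does, and what a methyl on the ring nitrogen would do. They also leave open whether the same methyl would weaken inhibition to a similar degree on the core of compound 3, with its 4-cyclopropylmethoxy-3-chlorophenyl group.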